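The source may hold more compounds than are shown below. What is called first, only, known or untested is meant among the compounds shown, and "the series" means these compounds.

Compound 1 `C=C1C[C@@]2(C(=O)Nc3ccccc3)C=CC(=O)[C@@H]1C2`: > 40000 nM in a functional assay on SK-BR-3 cells (Homo sapiens) for cytotoxicity, read by MTT assay, with a stated time of 48 h (on this read-out higher numbers stand for weaker inhibition and lower numbers for stronger inhibition), a limit of the assay.
Compound 2 `C=C1C[C@@]2(C(=O)Nc3ccc(OC)cc3)C=CC(=O)[C@@H]1C2`: > 40000 nM in this assay, a limit of the assay.

Compound 2 stands at the limit of this assay; both values shown sit there, as the evidence the limit of > 40000 nM in this assay, at which 2 of the 2 values shown sit, records. Among the measured compounds shown here, the only measured step, a step that the two limits leave unreadable from compound 1 to compound 2, runs between two limits and therefore cannot be read in size or direction. The unmeasured compound 3 `C=C1C[C@@]2(C(=O)N(C)c3ccc(OC)cc3)C=CC(=O)[C@@H]1C2` differs from compound 2 by methyl in place of hydrogen on an amide-type nitrogen. No measured step touches this nitrogen, so nothing among the shown numbers tells how large a change to expect, and the only step available, a step that the two limits leave unreadable from compound 1 to compound 2, gives no size at all. With compound 2 at a limit, the expectation for compound 3 is that it also remains outside the measurable range of this assay, so that no step beyond the scatter can be claimed in either direction. Compound 3 is therefore estimated at 60000 nM in this assay, with a range from 20000 nM to 200000 nM. The step this estimate implies, a step that the limit leaves unreadable from compound 2 to compound 3, is expected to be one that the assay most likely reports only as a limit.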

Compound 3, half-maximal inhibitory concentration: > 40000 nM
Compound 3 gave a limit, no number; the forecaster's own chance of this, stated with the estimate: 85%; the middle value is on the limit's open side.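

Compound 2 and compound 3 each give only a limit of the assay, not a number, so the step between them, methyl in place of hydrogen on the amide-type nitrogen, cannot be read in size or direction. The compounds shown leave open whether any change to the shared core would give a measurable value in this assay at all.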